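Removing the hydroxypyrrolidine from compound 2

The source may report more compounds than this note shows. Statements on the series, on what has been measured and on what is new or still open speak of the compounds shown alone.

Working notes on the series. Three compounds have numbers in an assay on isolated protein for inhibition of MAP kinase-activated protein kinase 2 (Homo sapiens), read by mobility shift assay, tested at 30 uM; on this read-out lower numbers stand for less inhibition and higher numbers for more inhibition at the one concentration tested (going by the name of the read-out). Compound 1 `COc1ccc(-c2cc3c(c(N)nn3C)c(=O)[nH]2)cc1` gives 51% in this assay. Compound 3 `Cc1[nH]c(=O)c2c(N)n(-c3ccccc3)nc2c1-c1ccccc1` gives 9%. Compound 2 `Cc1cc2c(c(N)nn2C)c(N2CC[C@H](O)C2)n1` gives 2%, the lowest of the three numbers; its gap to compound 3 lies within the scatter, while its gap to compound 1 lies beyond it, so on these numbers only compound 1 is separated from compound 2.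

Going by the values given here, no pair of measured compounds differs in a single place, so no measured step is available to carry over to a new compound. Compound 4 `Cc1cc2c(cn1)c(N)nn2C` has not yet been tested in this assay. Its difference from compound 2 is hydrogen in place of 3-hydroxypyrrolidin-1-yl on an aromatic carbon. The change sits on an aromatic carbon of a six-membered aromatic ring with 1 nitrogen, part of a fused or bridged system of two rings.

Among the compounds with values here, compound 2 already gives 2%, close to the bottom of the read-out, so little room remains downward, and nothing among the measured compounds points upward for this change. The expected step of a number 1 percentage points higher from compound 2 to compound 4 (within the scatter) is none beyond the scatter. Compound 4 is estimated at 3% in this assay, with a range from -5% to 15%.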

Compound 4, a percentage reported as inhibition, at one concentration (the size of the read-out at that concentration, not a potency): -2%
For compound 4 the middle estimate is 5 percentage points above the measured one; low and high end bracket the measured number.
By their numbers in this assay, from the lowest: compounds 4, 2 and 3 (each within the scatter of the next, the first and the last beyond it); then compound 1.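

Going by these compounds alone, the first one-place step, read in this assay, is a number 4 percentage points lower from compound 2 to compound 4 (within the scatter), so on an aromatic carbon of this six-membered aromatic ring with 1 nitrogen, hydrogen and 3-hydroxypyrrolidin-1-yl cannot be told apart. Stripping the group, with its ring, hydroxyl and defined stereocentre, uncovers no inhibition on this core: the number stays at the low end of the read-out with or without it. Nothing at hand bears on why the step is this small.

With both ends of the step near the bottom of the read-out, a loss at this position could hardly show, so the result does not establish that the position is indifferent to every substituent. From the compounds shown here alone, it remains open whether a different group on this aromatic carbon, such as a phenyl ring, an open-chain amine like dimethylamino or a carboxylic acid, would lift the number clear of the scatter on this core.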